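The source may report more compounds than this note shows. Statements on the series, on what has been measured and on what is new or still open speak of the compounds shown alone.

Working notes on the series.

Of the compounds shown here, three carry the shared core and have been tested in a functional assay on SW-620 cells (Homo sapiens) for inhibition, read by sulforhodamine B assay, with a stated time of 48 h; on this read-out higher numbers stand for weaker inhibition of growth and lower numbers for stronger inhibition of growth. Compound 1 `COc1ccc2[nH]c(-c3ccccc3)c(C=C(C#N)C#N)c2c1` gives 3600 nM. Compound 2 `COc1ccc(-c2[nH]c3ccc(OC)cc3c2C=C(C#N)C#N)cc1` gives 579 nM. Compound 3 `COc1ccc2[nH]c(-c3ccccc3)c(/C=C(\C#N)S(=O)(=O)c3ccccc3)c2c1` gives 4000 nM, the highest number of the three; against compound 1 the gap is within the scatter, against compound 2 it is beyond the scatter.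

Within the data shown here, the one single-point step among the measured compounds is a 6.2-fold higher number from compound 2 to compound 1 (0.79 log units; beyond the scatter). The difference is hydrogen in place of methoxy on an aromatic carbon

Compound 4 `N#C/C(=C\c1c(-c2ccccc2)[nH]c2ccccc12)S(=O)(=O)c1ccccc1` is not yet measured. It differs from compound 3 by hydrogen in place of methoxy on an aromatic carbon

How compound 3 differs from compound 2 is not broken down here; the two differ in more than one place.

The change from compound 3 to compound 4 is the same kind of change as that from compound 2 to compound 1, but not the same: in the earlier case the place is para to a large group on a six-membered aromatic ring of carbon only, whereas here it is on a six-membered aromatic ring of carbon only that is part of a fused or bridged system of two rings, meta to a fused ring and para to a fused ring. Among the measured compounds shown here, the earlier step is the only guide, and it rests on a single pair; a smaller step than that from compound 2 to compound 1 is expected here. In this assay the expected step is roughly a 1.8-fold higher number from compound 3 to compound 4 (0.24 log units; within the scatter), since compound 3 already stands at 4000 nM and the place of the change differs. Compound 4 is estimated at 7000 nM, with a range from 3000 nM to 20000 nM.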

Compound 4, concentration for 50% growth inhibition: 570 nM
Estimate against measurement, compound 4: 12-fold (1.09 log units) above; measured number outside the range, below it.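

In this assay, hydrogen in place of methoxy on the aromatic ring that is part of a fused or bridged system of two rings gives a 7.0-fold lower number from compound 3 to compound 4 (0.85 log units; beyond the scatter), so the change does not carry over from one core to the other with the same direction, and the step from the earlier pair cannot be applied unchanged: the same change on two cores in this assay, a 6.2-fold higher number (0.79 log units; beyond the scatter) from compound 2 to compound 1 and a 7.0-fold lower number (0.85 log units; beyond the scatter) from compound 3 to compound 4, 44-fold (1.64 log units) apart, beyond the scatter of two such steps

What this does not show is which difference between the two pairs matters, since they differ both in the place of the methoxy group and in the rest of the structure, and the two effects cannot be separated here. Each step also rests on a single pair, so nothing follows for this change at other places or on other cores, and the result gives no reason for the opposite directions.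

Still open, on these data alone, is whether the direction of the step follows the place of the change or the core, which would need the same place compared on both cores. Also open, as far as these compounds go, is how a hydroxyl group, a chlorine atom or an amine would read at the place on the ring that is part of the fused system, meta to a fused ring and para to a fused ring.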